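From Methoxy to Isopropoxy on a Shared Core

A few compounds are considered here, and "the series" means these few. Any claim that something is new, unique, unknown or untested is made for them only; others in the source may bear on it.

In an ADME assay on HEK293 cells (Homo sapiens) for cytotoxicity, read by CellTiter-Glo, with a stated time of 72 h (a higher number here means that more compound is needed for the effect, a lower number that less compound is needed), compound 1 `CC1=C2CC(C)(C)/C=C/[C@@H](O)/C(C)=C\C3=C[C@H](C)C[C@]3(O2)C1=O` gives 26000 nM, compound 2 `C/C1=C/C2=C[C@H](C)C[C@@]23O[C@]2(CC(C)(C)[C@@H](O)[C@@H]2C1=O)[C@@H](C)C3=O` gives 26000 nM, and compound 3 `CO[C@H]1[C@@H]2C(=O)/C(C)=C\C3=C[C@H](C)C[C@@]34O[C@]2(CC1(C)C)[C@@H](C)C4=O` gives 26000 nM, which places compound 3 level with the other two. Compound 4 `C/C1=C/C2=C[C@H](C)C[C@@]23O[C@]2(CC(C)(C)[C@@H](OC(C)C)[C@@H]2C1=O)[C@@H](C)C3=O` keeps the core of compound 3 and alters one group: isopropyl in place of methyl on an oxygen on a saturated carbon. Within the data shown here, one measured step bears on this oxygen, with methyl in place of hydrogen: no change at the digits printed from compound 2 to compound 3 (within the scatter). No group larger than methyl has been measured there, so this evidence is thin. On that basis, no shift beyond the scatter is expected, and the expected step is no change at the digits printed from compound 3 to compound 4 (within the scatter). For compound 4 the estimate is 26000 nM, with an expected range from 13000 nM to 50000 nM.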

Compound 4, half-maximal effective concentration: 26000 nM
Compound 4: the middle estimate sits on the measured number at the digits printed; the measured number falls inside the stated range.
By their numbers in this assay, from the lowest: compounds 1, 2, 3 and 4 (each within the scatter of the next).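

In this assay this oxygen has now carried hydrogen, methyl and isopropyl, so the comparison reaches beyond the single added methyl seen earlier. Exchanging methyl for isopropyl leaves the reading flat (no change at the digits printed from compound 3 to compound 4 (within the scatter)), and so does the larger jump from hydrogen to isopropyl (no change at the digits printed from compound 2 to compound 4 (within the scatter)). Nothing measured here explains this flat result.

Still open, from the compounds shown here alone, is whether a longer chain on this oxygen, or one ending in an amine or a carboxylic acid, would move the number. Changes elsewhere on the shared core also remain open.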